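The source may hold more compounds than are shown below. What is called first, only, known or untested is meant among the compounds shown, and "the series" means these compounds.

Measured in a functional assay on OCI-Ly3 cells (Homo sapiens) for inhibition, read by CellTiter-Glo, with stated times of 48 h and 96 h; a higher number here means a weaker inhibitor of growth, a lower number a stronger inhibitor of growth:
- Compound 1 `CCC(=O)[C@H](CCCNC(=N)N)NC(=O)[C@@H]1CCCN1C(=O)[C@@H](NC(=O)[C@H](CC(C)C)NC(=O)OCc1ccccc1)C(C)C`: > 20000 nM, a limit
- Compound 2 `CC(C)[C@H](NC(=O)OCc1ccccc1)C(=O)N1CCC[C@H]1C(=O)N(C)[C@@H](CCCNC(=N)N)C(=O)CF`: "not determined" (no result reported)
- Compound 3 `CC(C)[C@H](NC(=O)c1ccc(Br)cc1)C(=O)N1CCC[C@H]1C(=O)N[C@@H](CCCNC(=N)N)C(=O)CF`: 130 nM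

Compound 1 has the entry > 20000 nM, which is a limit and not a number. No result is reported for compound 2, whose entry reads "not determined" (no result reported). Among the compounds with values here, compound 3, at 130 nM, is the only compound with a single number in this assay, so there is no measured value to rank it against.

Compound 4 `CC(C)[C@H](NC(=O)C1CCCCC1)C(=O)N1CCC[C@H]1C(=O)N[C@@H](CCCNC(=N)N)C(=O)CF` has cyclohexyl in place of 4-bromophenyl on a carbonyl carbon, and the rest of compound 3 is unchanged: cyclohexyl in place of 4-bromophenyl on a carbonyl carbon. Within the data shown here, no measured step shows what such a change does in this assay, so the expectation rests on compound 3 at 130 nM alone. The estimated change is a 2.3-fold higher number from compound 3 to compound 4 (0.36 log units; beyond the scatter), a modest move toward weaker growth inhibition that stays close to the scatter. Compound 4 is expected at 300 nM, with an estimated range of 80 nM to 1500 nM.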

Compound 4, concentration for 50% growth inhibition: 940 nM
For compound 4 the middle estimate is 3.1-fold (0.50 log units) below the measured one; the range from low to high includes it.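

In this assay, within the data shown here, the change of 4-bromophenyl to cyclohexyl on a carbonyl carbon whose other neighbour is an amide-type nitrogen gives a 7.2-fold higher number from compound 3 to compound 4 (0.86 log units; beyond the scatter) and is the first step that can be read. It shows that growth inhibition at this position depends on the group carried there, yet compound 4 keeps a single measured number without the aromatic ring or the bromine. Among the values shown, compound 1 alone stands at a limit: the limit of > 20000 nM in this assay, at which 1 of the 4 values shown sits.

The step changes the ring and removes the bromine at once, so the compounds shown do not separate the two; unsubstituted phenyl or 4-chlorophenyl would bear on this. They also leave open how an amine or a carboxylic acid on the ring, or an open hexyl chain, would read at this position.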